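Dithiole thione and oxime analogues bearing a trimethoxyphenyl group

A few compounds are considered here, and "the series" means these few. Any claim that something is new, unique, unknown or untested is made for them only; others in the source may bear on it.

Measured so far:
compound 1 `COc1ccc(-c2ssc(=S)c2-c2cc(OC)c(OC)c(OC)c2)cc1` 4910 nM
compound 2 `COc1ccc(-c2ssc(=S)c2-c2cc(OC)c(OC)c(OC)c2)cc1O` 435 nM
compound 3 `COc1ccc(-c2ss/c(=N/O)c2-c2cc(OC)c(OC)c(OC)c2)cc1` 13700 nM

All three were run in a functional assay on KB cells (Homo sapiens) for antiproliferative activity, read by MTT assay, with a stated time of 72 h; a higher number here means a weaker inhibitor, a lower number a stronger inhibitor. Compound 3 has the highest number of the three; the difference between its core and that of compound 1 is not broken down here. For the measured compounds named here, the one paired step is hydroxy in place of hydrogen on an aromatic carbon, which gave an 11-fold lower number from compound 1 to compound 2 (1.05 log units; beyond the scatter).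

Compound 4 `COc1ccc(-c2ss/c(=N/O)c2-c2cc(OC)c(OC)c(OC)c2)cc1O` is not yet measured. It differs from compound 3 by hydroxy in place of hydrogen on an aromatic carbon, the same kind of change as that from compound 1 to compound 2, at a place described in the same words. Because of an 11-fold lower number from compound 1 to compound 2 (1.05 log units; beyond the scatter) a step of comparable size is expected, tempered only by the fact that the core of compound 3 is different, so the expected step is a 9.1-fold lower number from compound 3 to compound 4 (0.96 log units; beyond the scatter). For compound 4 the estimate in this assay is 1500 nM, between 400 nM and 6000 nM.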

Compound 4, half-maximal inhibitory concentration: 850 nM
For compound 4 the middle estimate is 1.8-fold (0.25 log units) above the measured one; low and high end bracket the measured number.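

In this assay, the change from 4-methoxyphenyl to 3-hydroxy-4-methoxyphenyl gave a 16-fold lower number from compound 3 to compound 4 (1.21 log units; beyond the scatter). The step carries across the two cores shown, with sizes that cannot be told apart: the same change on two cores in this assay, an 11-fold lower number (1.05 log units; beyond the scatter) from compound 1 to compound 2 and a 16-fold lower number (1.21 log units; beyond the scatter) from compound 3 to compound 4, 1.4-fold (0.15 log units) apart, within the scatter of two such steps. For the compounds shown here, this rests on only two pairs in one cell assay, so it shows neither that the step would hold on any further core nor why the hydroxy group has this effect.

Still open, as far as these compounds go, is whether another group in the same place, such as an amine or a fluorine atom, would give a step of like size. From the compounds shown here alone, the trimethoxyphenyl group is the same in all four compounds, so the role of its methoxy groups also remains open.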